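The source may hold more compounds than are shown below. What is called first, only, known or untested is meant among the compounds shown, and "the series" means these compounds.

Three compounds share a single core, and each is measured in a functional assay on M21 cells (Homo sapiens) for antiproliferative activity, read by sulforhodamine B assay, with a stated time of 48 h; a higher number here means a weaker inhibitor of growth, a lower number a stronger inhibitor of growth. Compound 1 `Cc1ccc(-c2cc(N3CCC(CNS(N)(=O)=O)CC3)ncn2)cc1` gives 71000 nM in this assay. Compound 2 `NS(=O)(=O)NCC1CCN(c2cc(-c3ccc(Cl)cc3)ncn2)CC1` gives 50300 nM, and compound 3 `NS(=O)(=O)NCC1CCN(c2cc(-c3cccc(Cl)c3)ncn2)CC1` gives 62500 nM. The three values sit close together: the step of a 1.4-fold lower number from compound 1 to compound 2 (0.15 log units; within the scatter) and the step of a 1.1-fold lower number from compound 1 to compound 3 (0.06 log units; within the scatter) are both within the scatter, as is the step of a 1.2-fold higher number from compound 2 to compound 3 (0.09 log units; within the scatter). Compound 3 therefore sits among its two neighbours rather than apart from them, and none of the three can be called stronger or weaker than another on these numbers.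

Compound 4 `NS(=O)(=O)NCC1CCN(c2cc(-c3ccccc3F)ncn2)CC1` has not yet been measured. It differs from compound 3 in one place: 2-fluorophenyl in place of 3-chlorophenyl on an aromatic carbon. The measured steps that bear on this change are those in which only the aryl ring attached to the shared core was altered, namely the steps from compound 1 to compound 2, from compound 1 to compound 3 and from compound 2 to compound 3, and every one of them stayed within the scatter. A further swap of the same aryl ring is therefore expected to produce a step of the size a 1.0-fold lower number from compound 3 to compound 4 (0.02 log units; within the scatter) in this assay, that is, no movement beyond the scatter. Compound 4 is accordingly estimated at 60000 nM, with a likely range from 30000 nM to 120000 nM.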

Compound 4, concentration for 50% growth inhibition: > 100000 nM
Compound 4: a limit, no number; the forecaster's own chance of this, stated with the estimate: 15%; middle value at least 1.6-fold (0.22 log units) away from the limit.
By their numbers in this assay, from the lowest: compounds 2, 3 and 1 (each within the scatter of the next). At a limit, above all of these: compound 4.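

In this assay, within the data shown here, compound 4 is the only one of the four compounds that ends at a limit of the assay rather than at a number: the limit of > 100000 nM in this assay, at which 1 of the 4 values shown sits. The steps to it are an at least 1.6-fold higher number from compound 3 to compound 4 (0.20 log units; that floor lies within the scatter), an at least 1.9-fold higher number from compound 2 to compound 4 (0.29 log units; that floor lies within the scatter) and an at least 1.4-fold higher number from compound 1 to compound 4 (0.14 log units; that floor lies within the scatter), and since each of these floors lies within the scatter, the true distance to compound 4 cannot be read. The aryl swaps among compounds 1, 2 and 3 all left measurable numbers within the scatter of one another, whereas the 2-fluorophenyl group on the same aromatic carbon of the shared core gives no number, so the earlier calm at this position does not carry over to every aryl ring, although a real loss of activity is not established.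

Compound 4 changes both the halogen and its place on the phenyl ring relative to compound 3, so the data cannot say which of the two counts, and chlorine in place of the fluorine of the 2-fluorophenyl group would separate them. As far as these compounds go, how a phenyl ring carrying an amine or a carboxylic acid would read at this position also stays open.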